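Replacing a methylcyclopropyl chain with isobutyl: expected clearance

The compounds below may be only part of what the source reports. "The series", "measured", "known", "first", "only" and "open" are said of these compounds alone.

Compound 1 `CC1(C[C@@H](O)C(=O)N2N=CC[C@H]2C(=O)NCc2cc(Cl)ccc2-n2cnnn2)CC1`: in an ADME assay on liver for metabolic stability, with Liver microsome (Homo sapiens) as the target, read by LC-MS, using microsomes (on this read-out lower numbers stand for slow clearance and higher numbers for fast clearance), compound 1 gives < 12 mL.min-1.g-1, which is a limit of the assay rather than a number.
Compound 2 `O=C(NCc1cc(Cl)ccc1-n1cnnn1)[C@@H]1[C@H]2C[C@H]2CN1C(=O)[C@H](O)c1ccccc1`: in this assay compound 2 gives 61 mL.min-1.g-1.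

Compound 1 thus sits at the limit of < 12 mL.min-1.g-1 in this assay, at which 1 of the 2 values shown sits, so its true clearance is known only as lying at that limit. Compound 3 `CC(C)CC[C@@H](O)C(=O)N1N=CC[C@H]1C(=O)NCc1cc(Cl)ccc1-n1cnnn1` differs from compound 1 by isobutyl in place of 1-methylcyclopropyl on a saturated chain carbon, two bonds along the chain from a carbonyl carbon and an oxygen on a saturated carbon. Among the compounds with values here, no measured pair shows this change, so only an expectation can be given: a modest step upward in this assay, possibly no more than the usual scatter, is expected, namely an at least 1.6-fold higher number from compound 1 to compound 3 (0.22 log units; that floor lies within the scatter). Compound 3 is therefore estimated at 20 mL.min-1.g-1, with a range from 8 mL.min-1.g-1 to 55 mL.min-1.g-1.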

Compound 3, intrinsic clearance in microsomes: 47 mL.min-1.g-1
Compound 3: the middle estimate sits 2.4-fold (0.37 log units) below what was measured, within the range that was stated.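

Here the change from 1-methylcyclopropyl to isobutyl, on a saturated chain carbon, two bonds along the chain from a carbonyl carbon and an oxygen on a saturated carbon, has a measured result: in this assay there is an at least 3.9-fold higher number from compound 1 to compound 3 (0.59 log units; beyond the scatter). The change removes the three-membered ring and leaves the count of 4 heavy atoms the same. That step is only a lower bound, as compound 1 stands at a limit of the assay: the limit of < 12 mL.min-1.g-1 in this assay, at which 1 of the 3 values shown sits.

On these data alone, whether a cyclobutyl or a tert-butyl group at this place would read like 1-methylcyclopropyl or like isobutyl stays open. So does whether the same change gives a similar step on another core.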